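Trimming an Amide Side Chain With Toxicity Expected Unchanged

A few compounds are considered here, and "the series" means these few. Any claim that something is new, unique, unknown or untested is made for them only; others in the source may bear on it.

Of the compounds shown here, two sharing a core have been tested in an ADME assay on HeLa cells (Homo sapiens) for cytotoxicity; on this read-out higher numbers stand for lower toxicity in this test and lower numbers for higher toxicity in this test. Compound 1, `COc1ccc(-c2c(C)nn3c(NCCNC(=O)C(C)C)cc(C)nc23)cc1OC`, carries an isopropylcarbonyl on its amide. In this assay compound 1 gives > 50000 nM, which is a limit of the assay rather than a number. Compound 2, `COc1ccc(-c2c(C)nc3c(NCCNC(C)=O)cc(Cl)nn23)cc1OC`, differs in its core and carries an acetamido side chain. In this assay compound 2 likewise reaches > 50000 nM, again a limit and not a measured number. Compound 1 thus stands at the limit of > 50000 nM in this assay, at which 2 of the 2 values shown sit, the edge of what this test can report. Going by the values given here, no step between two measured compounds with a single difference exists here. Compound 3, `COc1ccc(-c2c(C)nn3c(NCCNC(C)=O)cc(C)nc23)cc1OC`, is the next compound: methyl in place of isopropyl on a carbonyl carbon. The amide itself stays in place. Compound 3 is expected to show 50000 nM, within 20000 nM to 120000 nM. The expected step, a number no higher from compound 1 to compound 3 (the limit leaves the size open), amounts to none beyond the scatter, and compound 3 will most likely also be reported only as a limit.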

Compound 3, half-maximal cytotoxic concentration: > 50000 nM
Compound 3: only a limit was reported; the forecaster's own chance of this, stated with the estimate: 85%; the middle value lies on the limit itself.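

Compound 3 ends up like compound 1, with a limit of the assay rather than a number, so no step between compound 1 and compound 3 can be read: the limit of > 50000 nM in this assay, at which 3 of the 3 values shown sit.

On these data alone, whether methyl in place of isopropyl on a carbonyl carbon changes toxicity at all remains open.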